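The compounds below may be only part of what the source reports. "The series", "measured", "known", "first", "only" and "open" are said of these compounds alone.

Compound 1 `CN(C)CCCCOc1ccc2oc(-c3ccccc3)cc(=O)c2c1` and compound 2 `CN(C)CCCCCCCCOc1ccc2oc(-c3ccccc3)cc(=O)c2c1` share one core and differ only in the length of the saturated chain that carries the dimethylamino group. Among the measured compounds shown here, in an assay on isolated protein (Cavia porcellus) with Sigma non-opioid intracellular receptor 1 (Homo sapiens) as the target, read by radioligand binding (on this read-out lower numbers stand for stronger inhibition and higher numbers for weaker inhibition), compound 1 gives 720 nM and compound 2 gives 227 nM, so compound 2 holds the lowest of the two numbers so far; the step of a 3.2-fold lower number from compound 1 to compound 2 (0.50 log units; beyond the scatter) is the only measured step and it rewards the longer chain.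

Compound 3 `CN(C)CCCCCCCCCOc1ccc2oc(-c3ccccc3)cc(=O)c2c1` goes one bond further in the same direction: (dimethylamino)methyl in place of dimethylamino on a saturated chain carbon, eight bonds along the chain from an oxygen on an aromatic ring. For the measured compounds named here, the only bearing step, a 3.2-fold lower number from compound 1 to compound 2 (0.50 log units; beyond the scatter), covered a four-carbon lengthening, and a single added carbon is a much smaller change, so in this assay the expected step of a 1.4-fold lower number from compound 2 to compound 3 (0.15 log units; within the scatter) is a small lowering of the number, possibly not beyond the scatter. Compound 3 is therefore estimated at 160 nM, with a range of 70 nM to 360 nM.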

Compound 3, half-maximal inhibitory concentration: 334 nM
Compound 3: middle estimate off by 2.1-fold (0.32 log units), on the low side, within the range that was stated.
By their numbers in this assay, from the lowest: compounds 2 and 3 (each within the scatter of the next); then compound 1.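

In this assay one further chain carbon, (dimethylamino)methyl in place of dimethylamino, gives a 1.5-fold higher number from compound 2 to compound 3 (0.17 log units; within the scatter) and so leaves compound 2 and compound 3 unresolved: the reward for lengthening seen earlier does not visibly continue at this end of the chain. The longer change, 5-(dimethylamino)pentyl in place of dimethylamino at the position four bonds along the chain from the oxygen, still gives a 2.2-fold lower number from compound 1 to compound 3 (0.33 log units; beyond the scatter) and keeps compound 1 apart from both longer-chain compounds. Nothing at hand bears on why the chain length acts in this way.

Still open, on these data alone, is whether a longer chain on the shared core moves the number beyond the scatter. Also open, as far as these compounds go, is what a cyclic amine such as piperidine or morpholine does in place of the dimethylamino group, and how chains of intermediate length between those of compound 1 and compound 2 behave.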